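Isopropyl in place of iodo on the sulfur

A few compounds are considered here, and "the series" means these few. Any claim that something is new, unique, unknown or untested is made for them only; others in the source may bear on it.

Compound 1 `Nc1nc(SCc2ccc(F)cc2)c2ncn([C@@H]3O[C@H](CO)[C@@H](O)[C@H]3O)c2n1`: 1150 nM
Compound 2 `Nc1nc(SI)c2ncn([C@@H]3O[C@H](CO)[C@@H](O)[C@H]3O)c2n1`: 81300 nM

Of the compounds shown here, two have been measured in an assay on isolated protein for binding affinity to Equilibrative nucleoside transporter 1 (Homo sapiens); a lower number here means a stronger inhibitor, a higher number a weaker inhibitor. Compound 1 gives 1150 nM, and compound 2 gives 81300 nM. Within the data shown here, compound 2 stands at the highest of the two numbers; its nearest neighbour is compound 1, and the only step measured so far, a 71-fold higher number from compound 1 to compound 2 (1.85 log units; beyond the scatter), is large and beyond the scatter.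

Compound 3 `CC(C)Sc1nc(N)nc2c1ncn2[C@@H]1O[C@H](CO)[C@@H](O)[C@H]1O` is not yet measured. It differs from compound 2 by isopropyl in place of iodo on a sulfur. Among the measured compounds shown here, the one measured step that bears on this change is a 71-fold higher number from compound 1 to compound 2 (1.85 log units; beyond the scatter), which shows that replacing a carbon substituent on the sulfur by iodo raised the number greatly. The change from compound 2 to compound 3 reverses that direction by putting a carbon substituent back on the sulfur, though isopropyl is not 4-fluorobenzyl, so the size of the return is uncertain. A lower number than that of compound 2 is expected, and compound 3 is estimated at 8000 nM, within 1500 nM to 40000 nM, which is expected to mean a 10-fold lower number from compound 2 to compound 3 (1.01 log units; beyond the scatter).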

Compound 3, half-maximal inhibitory concentration: 191000 nM
For compound 3 the middle estimate is 24-fold (1.38 log units) below the measured one; measured number outside the range, above it.
By their numbers in this assay, from the lowest: compound 1; then compound 2; then compound 3.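

In this assay the result shows that a carbon group on the sulfur is not enough by itself to give a low number: isopropyl in place of iodo brings a 2.3-fold higher number from compound 2 to compound 3 (0.37 log units; beyond the scatter), a modest step that moves away from compound 1 rather than towards it. The low number of compound 1 therefore goes with the 4-fluorobenzyl group specifically and not with any carbon substituent at this place, as isopropyl in place of 4-fluorobenzyl brings a 170-fold higher number from compound 1 to compound 3 (2.22 log units; beyond the scatter), and compound 1 remains the strongest inhibitor of the three. Nothing in the data given explains why the 4-fluorobenzyl group stands apart from iodo and isopropyl.

The compounds shown leave open whether the low number of compound 1 rests on the ring of the 4-fluorobenzyl group or on its fluorine, which a plain benzyl group on the sulfur would help to separate. They also leave open where a longer chain such as n-butyl, or a phenethyl group, would stand relative to isopropyl and 4-fluorobenzyl.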